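Epoxide Configuration in a Depsipeptide Macrocycle Series

The compounds below may be only part of what the source reports. "The series", "measured", "known", "first", "only" and "open" are said of these compounds alone.

Working notes on four macrocyclic depsipeptides tested in a functional assay on PANC-1 cells (Homo sapiens) for antiproliferative activity; on this read-out higher numbers stand for weaker inhibition and lower numbers for stronger inhibition. Compound 1 `CC[C@H](C)[C@H]1C(=O)N[C@H](Cc2ccc(O)c(Br)c2)C(=O)N[C@@H](C(C)(C)O)C(=O)O[C@H](c2ccccc2)[C@H](C)/C=C/C=C(\C)[C@H](OC)C[C@H]2O[C@]2(C)C(=O)N1C` gives only a limit in this assay, > 200 nM, so its position is known only as a bound (the limit of > 200 nM in this assay, at which 1 of the 3 values shown sits). Compound 2 `CC[C@H](C)[C@H]1C(=O)N[C@H](Cc2cc(Cl)c(O)c(Cl)c2)C(=O)N[C@@H](C(C)C)C(=O)O[C@H](c2ccccc2)[C@H](C)/C=C/C=C(\C)[C@H](OC)C[C@@H]2O[C@@]2(C)C(=O)N1C` gives 15.5 nM in this assay. Compound 3 `CC[C@H](C)[C@H]1C(=O)N[C@H](Cc2cc(Cl)c(O)c(Cl)c2)C(=O)N[C@@H](C(C)C)C(=O)O[C@H](c2ccccc2)[C@H](C)/C=C/C=C(\C)[C@H](OC)C/C=C(\C)C(=O)N1C`, which carries an alkene in place of the epoxide ring, gives 137 nM in this assay.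

The step under review runs from compound 1 to compound 4 `CC[C@H](C)[C@H]1C(=O)N[C@H](Cc2ccc(O)c(Br)c2)C(=O)N[C@@H](C(C)(C)O)C(=O)O[C@H](c2ccccc2)[C@H](C)/C=C/C=C(\C)[C@H](OC)C[C@@H]2O[C@@]2(C)C(=O)N1C`, not yet measured. The change is the two compounds have the same atoms and bonds and differ only in configuration as drawn: 2 of 11 stereo elements differ; a stereocentre at a saturated ring carbon is drawn R in compound 1 and S in compound 4; a stereocentre at a saturated ring carbon is drawn S in compound 1 and R in compound 4. For the measured compounds named here, no measured pair in the set differs in one place only, so no step size is directly known. What can be read is that compound 2, whose drawing at the two saturated ring carbons matches compound 4, sits at a numerical value, while compound 1, drawn the opposite way, sits at the limit. On that basis a gain in potency is expected, beyond the usual scatter, in passing from compound 1 to compound 4, and the step of an at least 5.0-fold lower number from compound 1 to compound 4 (0.69 log units; beyond the scatter) expresses this expectation. Compound 4 is estimated at 40 nM in this assay, with a range from 10 nM to 160 nM.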

Compound 4, half-maximal inhibitory concentration: 9.61 nM
Beside the measured number, compound 4's estimate is 4.2-fold (0.62 log units) above it; measured number below the stated range.
By their numbers in this assay, from the lowest: compounds 4 and 2 (each within the scatter of the next); then compound 3. At a limit, above all of these: compound 1.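

In this assay, for the compounds shown here, the epoxide configuration now has a directly read effect: an at least 20-fold lower number from compound 1 to compound 4 (1.31 log units; beyond the scatter) is large and beyond the scatter, whereas no earlier pair isolated this change, and the series offered only an indirect reading from compounds that also differed elsewhere. The size of this step is open at its upper end, as compound 1 stands at a limit of the assay and not at a number: the limit of > 200 nM in this assay, at which 1 of the 4 values shown sits. The gain can be assigned to the drawn configuration at the two saturated ring carbons, taken together, because no atom or bond enters or leaves at this step: the fact that compounds 1 and 4 differ only in the configuration as drawn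

The two ring carbons change together here, so the compounds shown do not tell whether inverting either one alone would carry part of the step or all of it. They also leave open how this pair of configurations would read with an aziridine or a cyclopropane in place of the epoxide ring, and whether the step would keep its size on the shared core with other groups attached.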